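Swapping the Amide Substituent from Compound 2 to Compound 3

The source may hold more compounds than are shown below. What is called first, only, known or untested is meant among the compounds shown, and "the series" means these compounds.

Measured so far in an assay for inhibition of 6-phosphofructo-2-kinase/fructose-2,6-bisphosphatase 3 (Homo sapiens), read by ADP-Glo, with a stated time of 2 h; a lower number here means a stronger inhibitor, a higher number a weaker inhibitor:
compound 1, `CNS(=O)(=O)c1ccccc1Nc1cc(-c2ccc3ccn(C)c3c2)c2nccnc2c1`, gives 104 nM;
compound 2, `Cn1ccc2ccc(-c3cc(Nc4cnccc4C(=O)NCc4cncnc4)cc4nccnc34)cc21`, gives 106 nM.

In this assay compound 2 has the higher of the two numbers, but its nearest neighbour, compound 1, lies within the scatter of it, so the two values show no difference that can be read as an order. No stepwise comparison between measured compounds is available here.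

Compound 3, `CC(=O)N1CCC(NC(=O)c2ccncc2Nc2cc(-c3ccc4ccn(C)c4c3)c3nccnc3c2)CC1`, is the next compound, not yet measured. It differs from compound 2 in one place: 1-acetylpiperidin-4-yl in place of (pyrimidin-5-yl)methyl on an amide-type nitrogen.

For the measured compounds named here, with no measured step of this kind to lean on, the expected change from compound 2 to compound 3 in this assay is a 1.4-fold higher number from compound 2 to compound 3 (0.15 log units; within the scatter), not beyond the scatter in either direction. Compound 3 is therefore estimated at 150 nM, within a range of 50 nM to 450 nM.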

Compound 3, half-maximal inhibitory concentration: 18 nM
The estimate for compound 3 lay 8.3-fold (0.92 log units) above the measured number; the measured number lies below the stated range.
By their numbers in this assay, from the lowest: compound 3; then compounds 1 and 2 (each within the scatter of the next).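

The amide substituent turns out to matter in this assay: 1-acetylpiperidin-4-yl in place of (pyrimidin-5-yl)methyl on the amide-type nitrogen gives a 5.9-fold lower number from compound 2 to compound 3 (0.77 log units; beyond the scatter), the first single-place change available here and one that lies beyond the scatter. This one swap replaces an aromatic ring holding two hetero atoms with a non-aromatic ring holding one and also brings in an acetyl carbonyl, so the step cannot be assigned to any one of these features. No measurement at hand explains the gain.

Going by these compounds, it remains open whether the gain depends on the acetyl group, a question that a free piperidine amine or a methyl carbamate on that ring nitrogen could address. A plain cyclohexyl group could likewise test whether the non-aromatic ring alone is enough.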